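Stereochemistry and para-alkyl variation in the carbamate series

The source may report more compounds than this note shows. Statements on the series, on what has been measured and on what is new or still open speak of the compounds shown alone.

Measured compounds:
compound 1 `C=C1C(=O)OC[C@@H]1CCOC(=O)Nc1ccc(C(C)C)cc1` — 1580 nM
compound 2 `C=C1C(=O)OC[C@@H]1CCOC(=O)Nc1ccc(CC)cc1` — 1260 nM
compound 3 `C=C1C(=O)OC[C@H]1CCOC(=O)Nc1ccc(C(C)C)cc1` — 340 nM

In a functional assay on RAW264.7 cells (Mus musculus) for inhibition, with a stated time of 30 min (on this read-out lower numbers stand for stronger inhibition and higher numbers for weaker inhibition), compound 1 gives 1580 nM. The change to compound 2, (hydrogen in place of methyl on a saturated chain carbon bound to an aromatic carbon and a saturated chain carbon), moves the number a 1.3-fold lower number from compound 1 to compound 2 (0.10 log units; within the scatter). Going by the values given here, compound 3 differs from compound 1 only in drawn configuration, (the two compounds have the same atoms and bonds and differ only in configuration as drawn: 1 of 1 stereo elements differ; a stereocentre at a saturated ring carbon is drawn R in compound 1 and S in compound 3), and here the number moves a 4.6-fold lower number from compound 1 to compound 3 (0.67 log units; beyond the scatter); the only support for that step is the fact that compounds 1 and 3 differ only in the configuration as drawn. Compound 3 holds the lowest number of the three.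

Compound 4 `C=C1C(=O)OC[C@H]1CCOC(=O)Nc1ccc(CC)cc1` is the not yet measured partner: from compound 3 it carries the same change as from compound 1 to compound 2, (hydrogen in place of methyl on a saturated chain carbon bound to an aromatic carbon and a saturated chain carbon), on the same place and on the core of compound 3. On the basis of the step from compound 1 to compound 2 being within scatter, a step of about a 1.2-fold lower number from compound 3 to compound 4 (0.07 log units; within the scatter) is expected, essentially flat. Compound 4 is accordingly estimated at 290 nM in this assay, with a range from 120 nM to 700 nM.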

Compound 4, half-maximal inhibitory concentration: 840 nM
Compound 4: the middle estimate sits 2.9-fold (0.46 log units) below what was measured; measured number outside the range, above it.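

In this assay, the step on the core of compound 3 is a 2.5-fold higher number from compound 3 to compound 4 (0.39 log units; beyond the scatter), so isopropyl to ethyl does not carry over as a constant step from the core of compound 1 to the core of compound 3: the same change on two cores in this assay, a 1.3-fold lower number (0.10 log units; within the scatter) from compound 1 to compound 2 and a 2.5-fold higher number (0.39 log units; beyond the scatter) from compound 3 to compound 4, 3.1-fold (0.49 log units) apart, beyond the scatter of two such steps

With ethyl, the change of drawn configuration gives a 1.5-fold lower number from compound 2 to compound 4 (0.18 log units; within the scatter), so the separation seen in the isopropyl pair is not established for the ethyl pair: the fact that compounds 2 and 4 differ only in the configuration as drawn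

These two pairs show that the step depends on the core for this one change, but they do not show why, nor how any other change would carry across.

Going by these compounds, whether the same dependence holds for a tert-butyl group or a longer chain in place of isopropyl remains open. Also open, on these data alone, is whether either configuration would keep its order with such groups.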